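The compounds below may be only part of what the source reports. "The series", "measured", "known", "first", "only" and "open" are said of these compounds alone.

Measured so far in an ADME assay on MRC5 cells (Homo sapiens) for cytotoxicity, read by neutral red uptake; a higher number here means that more compound is tolerated, a lower number that less compound is tolerated:
- compound 1 `O=c1[nH]c(SCc2cc([N+](=O)[O-])cc([N+](=O)[O-])c2)nc2ccccc12`: > 64000 nM
- compound 2 `O=c1[nH]c(SCc2cccc([N+](=O)[O-])c2)nc2ccccc12`: > 64000 nM

Both entries are limits of the assay, not numbers. Compound 2 stands at > 64000 nM, which is a limit. For the measured compounds named here, the whole series so far shares one limit (the limit of > 64000 nM in this assay, at which 2 of the 2 values shown sit), so no true value is known for either compound.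

Compound 3 `O=c1[nH]c(SCc2cc([N+](=O)[O-])cc(C(F)(F)F)c2)nc2ccccc12` differs from compound 2 by one change, trifluoromethyl in place of hydrogen on an aromatic carbon.

Going by the values given here, only one measured step bears on this, a step that the two limits leave unreadable from compound 1 to compound 2, where hydrogen replaces nitro on an aromatic carbon. It gives no size to carry over. Compound 1 carries that extra group and still gives > 64000 nM, again a limit. No step beyond the scatter is therefore expected in this assay, and no direction can be named: the estimated step is a number no higher from compound 2 to compound 3 (the limit leaves the size open) and it may well go unread. For compound 3 the expected value is 64000 nM, within an estimated range of 30000 nM to 100000 nM, most likely reported as a limit again.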

Compound 3, half-maximal cytotoxic concentration: > 64000 nM
Compound 3 was reported as a limit; the forecaster's own chance of this, stated with the estimate: 80%; the middle value lies on the limit itself.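

In this assay compound 3 gives > 64000 nM, which is a limit and not a number. No step among compound 1, compound 2 and compound 3 can be read: the limit of > 64000 nM in this assay, at which 3 of the 3 values shown sit.

The compounds shown leave open how much of each compound the cells truly tolerate, and whether swapping hydrogen, nitro or trifluoromethyl changes that at all.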